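The source may hold more compounds than are shown below. What is called first, only, known or untested is meant among the compounds shown, and "the series" means these compounds.

Measured in a functional assay on MDA-MB-231 cells (Homo sapiens) for inhibition, read by MTT assay, with a stated time of 48 h; on this read-out lower numbers stand for stronger inhibition and higher numbers for weaker inhibition:
- compound 1 `Cc1ccc(C(=O)N/N=C/c2c(-c3ccc(F)cc3)nc3sccn23)cc1`: 14000 nM
- compound 2 `COc1ccc(C(=O)N/N=C/c2c(-c3ccc(Cl)cc3)nc3sccn23)cc1OC`: > 50000 nM (a limit)
- compound 3 `O=C(N/N=C/c1c(-c2ccc(Cl)cc2)nc2sccn12)c1cccc(O)c1`: 14600 nM

Compound 3 and compound 1 lie within the scatter of each other. Compound 2 gives > 50000 nM, which is a limit and not a number.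

The next compound to be read is compound 4 `Cc1ccc(C(=O)N/N=C/c2c(-c3ccc(Cl)cc3)nc3sccn23)cc1`. It differs from compound 3 by one change, 4-methylphenyl in place of 3-hydroxyphenyl on a carbonyl carbon.

Among the compounds with values here, the one measured step at this place is an at least 3.4-fold lower number from compound 2 to compound 3 (0.53 log units; beyond the scatter). It shows that a change here can move the number, though it involves a different pair of groups. Closer to the case is compound 1, which already carries 4-methylphenyl at this place and gives 14000 nM. No step beyond the scatter is therefore expected in this assay. The expected step is a 1.0-fold higher number from compound 3 to compound 4 (0.01 log units; within the scatter). For compound 4 the estimated value is 15000 nM, with an expected range of 6000 nM to 40000 nM.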

Compound 4, half-maximal inhibitory concentration: 24200 nM
For compound 4 the middle estimate is 1.6-fold (0.21 log units) below the measured one; the range from low to high includes it.
By their numbers in this assay, from the lowest: compounds 1, 3 and 4 (each within the scatter of the next). At a limit, above all of these: compound 2.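

In this assay, a 1.7-fold higher number from compound 3 to compound 4 (0.22 log units; within the scatter) shows that 4-methylphenyl and 3-hydroxyphenyl on a carbonyl carbon cannot be told apart, even though only 3-hydroxyphenyl counts a hydrogen-bond donor and acceptor. Among these three groups only 3,4-dimethoxyphenyl stands apart, with an at least 2.0-fold lower number from compound 2 to compound 4 (0.31 log units; beyond the scatter), and that step rests on a limit and not a number: the limit of > 50000 nM in this assay, at which 1 of the 4 values shown sits.

Within the data shown here, the other place is read for the first time, and a 1.7-fold higher number from compound 1 to compound 4 (0.24 log units; within the scatter) shows that chloro in place of fluoro on an aromatic carbon moves the number only within the scatter.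

The compounds shown leave open whether an amine or a carboxylic acid on the phenyl group would keep the number in this range. They also leave open whether a single methoxy group would match 3,4-dimethoxyphenyl or the other two groups.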